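Shortening an Ethyl to a Methyl on the Aryl Group

A few compounds are considered here, and "the series" means these few. Any claim that something is new, unique, unknown or untested is made for them only; others in the source may bear on it.

Compound 1 `CCOC(=O)c1cnc2scc(C3=CCCCC3)n12` and compound 2 `CCOC(=O)c1cnc2scc(-c3ccc(CC)cc3)n12` share the same core and differ only in the group attached to it. In an assay on isolated protein for inhibition of Indoleamine 2,3-dioxygenase 1 (Homo sapiens), with a stated time of 30 min (on this read-out higher numbers stand for weaker inhibition and lower numbers for stronger inhibition), compound 1 reaches only a limit, > 100000 nM, which is a boundary of the assay and not a number. For the measured compounds named here, compound 2 gives 24000 nM in this assay, the only number available so far. Going by the values given here, compound 2 therefore stands as the single compound with a measured value, the other entry being a limit (the limit of > 100000 nM in this assay, at which 1 of the 2 values shown sits). Compound 3 `CCOC(=O)c1cnc2scc(-c3ccc(C)cc3)n12` differs from compound 2 by hydrogen in place of methyl on a saturated chain carbon bound to an aromatic carbon, so the ethyl becomes a methyl. Among the compounds with values here, no step between two measured compounds exists for comparison. For so small a change, a step of little size is expected in this assay, possibly none beyond the scatter. The estimate for compound 3 is 35000 nM, with a range from 12000 nM to 100000 nM. This corresponds to an expected step of a 1.5-fold higher number from compound 2 to compound 3 (0.16 log units; within the scatter).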

Compound 3, half-maximal inhibitory concentration: 18000 nM
The estimate for compound 3 lay 1.9-fold (0.29 log units) above the measured number, and the stated range covers the measured number.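

For the compounds shown here, this is the first step that can be read between two measured compounds: on the aryl group, shortening the ethyl to a methyl gives a 1.3-fold lower number from compound 2 to compound 3 (0.12 log units; within the scatter) in this assay. Removing this one chain carbon therefore leaves the read-out within the normal variation of repeated measurements, and compound 2 and compound 3 cannot be told apart here. Nothing measured here says why the chain length at this place has so little effect.

Still open, from the compounds shown here alone, is whether a longer chain such as butyl, an amine or a carboxylic acid at this place would shift the number beyond the scatter. Going by these compounds alone, the value of compound 1 remains a limit and not a number, so no step to it can be read.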